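The compounds below may be only part of what the source reports. "The series", "measured", "known", "first", "only" and "open" are said of these compounds alone.

Measured values in a functional assay on HepG2 cells (Homo sapiens) for inhibition, read by MTT assay, with a stated time of 72 h; a higher number here means a weaker inhibitor, a lower number a stronger inhibitor:

compound 1 `COc1ccc(/C=N/NC(=O)c2sc(N(C)C(=O)NC(=O)c3c(F)cccc3F)nc2C)cc1`: 22.7 ug/mL
compound 2 `CNc1nc(C(F)(F)F)c(C(=O)N/N=C/c2ccccc2C(F)(F)F)s1`: > 100 ug/mL
compound 3 `CNc1nc(C)c(C(=O)N/N=C/c2cccc(C(F)(F)F)c2)s1`: > 100 ug/mL

Compound 3 stands at the limit of > 100 ug/mL in this assay, at which 2 of the 3 values shown sit; its entry is a limit of the assay and not a number. Compound 2 also sits at the limit with > 100 ug/mL. Only compound 1, built on a different core, returns a measured number with 22.7 ug/mL. Within the data shown here, no step between two measured compounds is available, so the change leading to compound 4 `CNc1nc(C)c(C(=O)N/N=C/c2cc(C(F)(F)F)cc(C(F)(F)F)c2)s1` has no measured neighbour to be set against. The change is trifluoromethyl in place of hydrogen on an aromatic carbon. With the parent already at the limit, the series gives no calibration for a second trifluoromethyl group on the same ring, and no reason to expect movement beyond the scatter. The step is therefore expected as a step that the limit leaves unreadable from compound 3 to compound 4, that is, no change beyond the scatter in either direction. Compound 4 is expected at 120 ug/mL, with a range from 40 ug/mL to 400 ug/mL, most probably reported again only as a limit.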

Compound 4, half-maximal inhibitory concentration: > 100 ug/mL
Compound 4 ended at the assay's limit (the forecaster's own chance of this, stated with the estimate: 70%); the middle value does not contradict the limit.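

The step from compound 3 to compound 4 cannot be read, since both entries are limits and not numbers: the limit of > 100 ug/mL in this assay, at which 3 of the 4 values shown sit.

Going by these compounds, whether trifluoromethyl in place of hydrogen on an aromatic carbon changes inhibition at all stays open, as does which feature of compound 1 goes with its measured number.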